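The compounds below may be only part of what the source reports. "The series", "measured", "known", "first", "only" and "open" are said of these compounds alone.

In an ADME assay on Vero cells (Chlorocebus sabaeus) for cytotoxicity, read by MTT assay, with a stated time of 72 h (a higher number here means that more compound is needed for the effect, a lower number that less compound is needed), compound 1 `O=C(Nc1nc(-c2ccccn2)cs1)c1cccc(Br)c1` gives 16100 nM, compound 2 `O=C(Nc1nc(-c2ccccn2)cs1)c1ccc(Br)cc1` gives 4700 nM and compound 3 `O=C(Nc1nc(-c2ccccn2)cs1)c1cccc(Cl)c1` gives 7000 nM. The low end of this short series is a pair separated only by a 1.5-fold higher number from compound 2 to compound 3 (0.17 log units; within the scatter). Compound 4 `O=C(Nc1nc(-c2ccccn2)cs1)c1cccc(F)c1` carries fluoro in place of chloro on an aromatic carbon. For the measured compounds named here, the one measured halogen exchange at this place is a 2.3-fold lower number from compound 1 to compound 3 (0.36 log units; beyond the scatter), a modest step, and a single step sets no trend. The other steps also move the halogen or start from it elsewhere, so they bear less directly. The expected change is small and slightly downward, a 1.2-fold lower number from compound 3 to compound 4 (0.07 log units; within the scatter). For compound 4 the estimated value in this assay is 6000 nM, with an expected range of 2500 nM to 16000 nM.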

Compound 4, half-maximal effective concentration: 1200 nM
Beside the measured number, compound 4's estimate is 5.0-fold (0.70 log units) above it; measured number below the stated range.
By their numbers in this assay, from the lowest: compound 4; then compounds 2 and 3 (each within the scatter of the next); then compound 1.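

In this assay, the exchange of chloro for fluoro at this place is no small adjustment (a 5.8-fold lower number from compound 3 to compound 4 (0.77 log units; beyond the scatter)), and it continues in the same direction as the earlier exchange of bromo for chloro (a 2.3-fold lower number from compound 1 to compound 3 (0.36 log units; beyond the scatter)). Across these three halogens the number falls in order, and the whole exchange from bromo to fluoro is a large step (a 13-fold lower number from compound 1 to compound 4 (1.13 log units; beyond the scatter)). The 3-fluorophenyl compound also lies clear of the 4-bromophenyl one (a 3.9-fold lower number from compound 2 to compound 4 (0.59 log units; beyond the scatter)), so compound 4 is the lowest of the four. Going by these compounds, whether an amine or a methoxy group at this place would extend the fall remains open. Nothing available accounts for the fall in the number.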